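The compounds below may be only part of what the source reports. "The series", "measured", "known", "first", "only" and "open" are said of these compounds alone.

Measured compounds:

Compound 1, `O=C(Nc1cccc(-n2cc(-c3ccncc3)c(-c3ccc(Cl)c(O)c3)n2)c1)Nc1cccc(C(F)(F)F)c1`: in a functional assay on DU-145 cells (Homo sapiens) for inhibition, read by sulforhodamine B assay, with a stated time of 48 h (on this read-out lower numbers stand for stronger inhibition of growth and higher numbers for weaker inhibition of growth), compound 1 gives > 32500 nM, which is a limit of the assay and not a number.

Compound 2, `COc1cc(-c2nn(-c3cccc(NC(=O)Nc4cc(C(F)(F)F)cc(C(F)(F)F)c4)c3)cc2-c2ccncc2)ccc1Cl`: in this assay compound 2 gives 5040 nM.

For the measured compounds named here, compound 2 stands as the only compound with an actual number in this assay; the one further value shown is a limit, (the limit of > 32500 nM in this assay, at which 1 of the 2 values shown sits). Going by the values given here, no step between measured compounds that differ in a single place is available, so the expectation for the next compound rests on these two values alone.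

Compound 3, `O=C(Nc1cccc(-n2cc(-c3ccncc3)c(-c3ccc(Cl)c(O)c3)n2)c1)Nc1cc(C(F)(F)F)cc(C(F)(F)F)c1`, differs from compound 2 by hydrogen in place of methyl on an oxygen on an aromatic ring, methoxy to hydroxy, 4-chloro-3-methoxyphenyl to 4-chloro-3-hydroxyphenyl. Compound 1 also carries the hydroxy group and sits only at the limit, (the limit of > 32500 nM in this assay, at which 1 of the 2 values shown sits), so a loss of inhibitory strength relative to compound 2 is expected for compound 3, rather than a change within the scatter. Compound 3 is estimated at 15000 nM, within a range from 5000 nM to 40000 nM. This expected step, a 3.0-fold higher number from compound 2 to compound 3 (0.47 log units; beyond the scatter), would lie beyond the usual scatter, toward weaker inhibition of growth.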

Compound 3, concentration for total growth inhibition: 5620 nM
Compound 3: the middle estimate sits 2.7-fold (0.43 log units) above what was measured, and the stated range covers the measured number.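

In this assay, the change from methoxy to hydroxy on the 4-chloro-3-methoxyphenyl group can now be read as a single change, and it gives a 1.1-fold higher number from compound 2 to compound 3 (0.05 log units; within the scatter), so the two groups cannot be told apart at this position in this assay. The hydroxy group alone therefore does not go with the loss of growth inhibition seen for compound 1, whose value is a limit of the assay and not a number: the limit of > 32500 nM in this assay, at which 1 of the 3 values shown sits. With the hydroxy group kept, trifluoromethyl in place of hydrogen on an aromatic carbon gives an at least 5.7-fold lower number from compound 1 to compound 3 (0.76 log units; beyond the scatter), which makes this the only change among those shown with a step beyond the scatter.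

Going by these compounds, the true size of that trifluoromethyl step remains open, as does whether it would hold with methoxy in place of hydroxy. Also open, on these data alone, is whether a longer chain on the oxygen, such as ethoxy, or an amine in place of the hydroxy group would leave the value in this range.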